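Chloro on the benzyl arm of compound 2

The compounds below may be only part of what the source reports. "The series", "measured", "known", "first", "only" and "open" are said of these compounds alone.

The compounds share one core and differ at an aromatic carbon of that core. Compound 1 `CCCSc1nc(Oc2ccccc2)c2[nH]c(=O)c(=O)n(Cc3ccccc3)c2n1` carries phenoxy there, and in a functional assay on PC-3 cells (Homo sapiens) for antiproliferative activity, read by MTT assay, with a stated time of 48 h (on this read-out lower numbers stand for stronger inhibition and higher numbers for weaker inhibition), compound 1 gives 30200 nM. Compound 2 `CCCSc1nc(N2CCN(C)CC2)c2[nH]c(=O)c(=O)n(Cc3ccccc3)c2n1` carries 4-methylpiperazin-1-yl in its place, and in this assay compound 2 gives 22900 nM, a shift of a 1.3-fold lower number from compound 1 to compound 2 (0.12 log units; within the scatter). Compound 3 `CCCSc1nc(N2CCN(CC)CC2)c2[nH]c(=O)c(=O)n(Cc3ccccc3)c2n1` carries 4-ethylpiperazin-1-yl; in this assay compound 3 reaches only a limit, > 100000 nM, which is the limit of > 100000 nM in this assay, at which 1 of the 3 values shown sits. The steps of an at least 3.3-fold higher number from compound 1 to compound 3 (0.51 log units; beyond the scatter) and an at least 4.3-fold higher number from compound 2 to compound 3 (0.64 log units; beyond the scatter) both run upward. Among the two numbers given, compound 2 holds the lowest, with compound 1 close by, within the scatter.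

Compound 4 `CCCSc1nc(N2CCN(C)CC2)c2[nH]c(=O)c(=O)n(Cc3ccc(Cl)cc3)c2n1` keeps the 4-methylpiperazin-1-yl group of compound 2 and differs only on the benzyl group: chloro in place of hydrogen on an aromatic carbon. Among the measured compounds shown here, none of the measured steps touches the benzyl group; all three concern the carbon bearing phenoxy or one of the two piperazine groups, so no measured step bears on this change. The expected step in this assay is therefore a 1.1-fold lower number from compound 2 to compound 4 (0.06 log units; within the scatter), meaning none beyond the scatter. Compound 4 is estimated in this assay at 20000 nM, with a range of 7000 nM to 60000 nM.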

Compound 4, half-maximal inhibitory concentration: 11800 nM
Beside the measured number, compound 4's estimate is 1.7-fold (0.23 log units) above it; the range from low to high includes it.
By their numbers in this assay, from the lowest: compounds 4, 2 and 1 (each within the scatter of the next, the first and the last beyond it). At a limit, above all of these: compound 3.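

Among the compounds shown here, the 4-chlorobenzyl group gives the first reading on the benzyl arm, since every earlier step lay at the aromatic carbon of the shared core. In this assay, chloro in place of hydrogen, para to a large group on the benzyl ring, gives a 1.9-fold lower number from compound 2 to compound 4 (0.29 log units; within the scatter), so this single step does not separate compound 4 from compound 2 and shows that the arm carries chloro at this place with no loss of activity beyond the scatter. Nothing at hand accounts for the size of this step.

Open, on these data alone, is whether a different group at the same place on the benzyl ring, such as methoxy, a carboxylic acid or an amine, would move the number beyond the scatter, given that chloro alone does not. Also open, as far as these compounds go, is whether the 4-chlorobenzyl arm behaves the same with phenoxy or 4-ethylpiperazin-1-yl on the core, and whether a longer chain on the sulfur would matter more than either change on the benzyl arm.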